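The source may hold more compounds than are shown below. What is called first, only, known or untested is meant among the compounds shown, and "the series" means these compounds.

Antiproliferative results in a functional assay on A549 cells (Homo sapiens) for antiproliferative activity, read by MTT assay, with a stated time of 72 h; on this read-out higher numbers stand for weaker inhibition and lower numbers for stronger inhibition:

compound 1 `CCCCCCCCCCCCNC[C@@H]1OC[C@H](N)[C@H]1O`: 41100 nM
compound 2 `CCCCCCCNC[C@@H]1OC[C@H](N)[C@H]1O`: > 128000 nM (a limit of the assay, not a number)

Compound 2 has no exact position on these numbers. It carries only the limit > 128000 nM, which is the limit of > 128000 nM in this assay, at which 1 of the 2 values shown sits.

Compound 3 `CCCCCCCCNC[C@@H]1OC[C@H](N)[C@H]1O`, not yet measured in this assay, departs from compound 2 by a single change: methyl in place of hydrogen on a saturated chain carbon, seven bonds along the chain from an amine nitrogen. In words, this is methyl in place of hydrogen on a saturated chain carbon, seven bonds along the chain from an amine nitrogen.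

Going by the values given here, one measured step bears on this change, since it falls at the same place on the chain: an at least 3.1-fold higher number from compound 1 to compound 2 (0.49 log units; beyond the scatter). That step lies beyond the scatter and removes pentyl, whereas the new change adds only methyl. The direction it suggests for adding carbon is towards a lower number, so a small shift that way is expected, possibly no larger than the scatter. The expected step is an at least 1.1-fold lower number from compound 2 to compound 3 (0.06 log units; that floor lies within the scatter). The value estimated for compound 3 is 110000 nM, with an expected range from 60000 nM to 220000 nM.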

Compound 3, half-maximal inhibitory concentration: 71800 nM
For compound 3 the middle estimate is 1.5-fold (0.19 log units) above the measured one; the measured number falls inside the stated range.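

In this assay the step for methyl in place of hydrogen at this place on the chain is an at least 1.7-fold lower number from compound 2 to compound 3 (0.25 log units; that floor lies within the scatter) and so gives compound 3 a measured number where compound 2 has none. That step is only a floor and its true size cannot be read, because compound 2 carries a limit and not a number: the limit of > 128000 nM in this assay, at which 1 of the 3 values shown sits. The earlier step of an at least 3.1-fold higher number from compound 1 to compound 2 (0.49 log units; beyond the scatter) lay beyond the scatter, whereas the new step of a 1.7-fold higher number from compound 1 to compound 3 (0.24 log units; within the scatter) stays within it, so among these compounds taking off butyl leaves no readable difference where taking off pentyl did.

The compounds shown leave open where compound 2 really lies on this read-out, and so how much of the difference from compound 1 the single methyl accounts for. They also leave open how a chain longer than that of compound 1, or a hydroxyl group or an amine at the far end of the chain, would behave in this assay.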